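A few compounds are considered here, and "the series" means these few. Any claim that something is new, unique, unknown or untested is made for them only; others in the source may bear on it.

Compound 2 `N#C/C(=C\N1CCN(C(=O)c2ccco2)C1=S)C(N)=O` carries a carbamoyl group at the end of the chain. Among the measured compounds shown here, in a functional assay on NCI-H23 cells (Homo sapiens) for inhibition, read by sulforhodamine B assay, with a stated time of 48 h (a higher number here means a weaker inhibitor of growth, a lower number a stronger inhibitor of growth), compound 2 gives 21400 nM, the higher of the two numbers known so far. For the measured compounds named here, its only neighbour, compound 1 `N#C/C(=C\N1CCN(C(=O)c2ccco2)C1=S)C(=O)Nc1ccc(Cl)cc1`, carries a 4-chlorophenyl on the amide-type nitrogen instead, and in this assay compound 1 gives 12300 nM. Going by the values given here, the step of a 1.7-fold higher number from compound 1 to compound 2 (0.24 log units; within the scatter) is the sole measured step and lies within the scatter. Compound 3 `N#C/C(=C\N1CCN(C(=O)c2ccco2)C1=S)C(=O)c1ccccc1` has not yet been measured; it differs from compound 2 by phenyl in place of amino on a carbonyl carbon. Among the compounds with values here, the one measured step touches the same end of the molecule, and its size shows that taking an aryl group away there left the number unchanged within the scatter, so putting an aryl group back on the carbonyl carbon gives no ground to expect a step beyond the scatter. Compound 1, with 12300 nM, points if anything towards a slightly lower number. Compound 3 is therefore expected to move by a 1.5-fold lower number from compound 2 to compound 3 (0.18 log units; within the scatter). Compound 3 is estimated at 14000 nM in this assay, within a range from 5000 nM to 40000 nM.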

Compound 3, concentration for 50% growth inhibition: 15200 nM
Beside the measured number, compound 3's estimate is 1.1-fold (0.04 log units) below it; the range from low to high includes it.
By their numbers in this assay, from the lowest: compounds 1, 3 and 2 (each within the scatter of the next).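

In this assay, the earlier step had only removed an aryl group from the amide-type nitrogen, whereas this change replaces the amino group itself, so that carbamoyl becomes benzoyl, one hydrogen-bond donor leaves and a six-membered aromatic ring enters on the carbonyl carbon, giving a 1.4-fold lower number from compound 2 to compound 3 (0.15 log units; within the scatter). Replacing the whole (4-chlorophenyl)amino group with phenyl on that same carbon gives a 1.2-fold higher number from compound 1 to compound 3 (0.09 log units; within the scatter), so neither the nitrogen nor the chlorine is needed to keep the number within the scatter, and amino, phenyl and (4-chlorophenyl)amino on this carbon cannot be told apart in this assay. No evidence is available that would explain this result.

The compounds shown therefore leave open whether any group on this carbonyl carbon can move the number beyond the scatter, for example a hydroxyl giving a carboxylic acid, a methoxy giving a methyl ester, or a longer chain such as benzylamino. They also leave open whether changes elsewhere on the shared core would have a larger effect than those at this end of the molecule.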